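Swapping the Formyl Group of Compound 2 for Hydrogen

The source may report more compounds than this note shows. Statements on the series, on what has been measured and on what is new or still open speak of the compounds shown alone.

Compound 1 `C=CCc1cc(-c2ccccc2C(F)(F)F)ccc1O`: 60300 nM
Compound 2 `C=CCc1cc(C=O)c(OCC)c(-c2ccc(OCC)c(CC=C)c2)c1`: 31900 nM

In a functional assay on Lewis lung carcinoma cells (Mus musculus) for antiproliferative activity, read by MTT assay, with a stated time of 24 h (on this read-out lower numbers stand for stronger inhibition and higher numbers for weaker inhibition), compound 2 gives 31900 nM and compound 1 gives 60300 nM. These two values lie within the usual scatter of each other, so the numbers cannot separate them.

Compound 3 `C=CCc1ccc(OCC)c(-c2ccc(OCC)c(CC=C)c2)c1` has not yet been measured. It differs from compound 2 by one change: hydrogen in place of formyl on an aromatic carbon. Hydrogen takes the place of formyl on an aromatic carbon, ortho to an ethoxy group.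

Going by the values given here, no measured pair shows this change alone, so its size is uncertain. Compound 1 and compound 2 have quite different structures, yet the values of compound 1 at 60300 nM and compound 2 at 31900 nM stay close. On that basis, no step beyond the scatter is expected in this assay. The estimated change is a 1.1-fold higher number from compound 2 to compound 3 (0.04 log units; within the scatter).

For compound 3, the expected value is 35000 nM, with an estimated range of 15000 nM to 80000 nM.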

Compound 3, half-maximal inhibitory concentration: > 124000 nM
Compound 3 gave a limit, no number (the forecaster's own chance of this, stated with the estimate: 10%); at least 3.5-fold (0.54 log units) between middle value and limit.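

Taking the formyl group off this aromatic carbon, ortho to an ethoxy group, is not a silent change: in this assay the swap to hydrogen gives an at least 3.8-fold higher number from compound 2 to compound 3 (0.58 log units; beyond the scatter), so in this pair the stronger inhibition goes with the formyl group. For compound 3, > 124000 nM is a limit of the assay and not a number. The full size of the step therefore stays unknown, because the reading for compound 3 stops at that limit: the limit of > 124000 nM in this assay, at which 1 of the 3 values shown sits.

With only formyl and hydrogen shown at this carbon, it remains open whether the formyl group itself matters or whether other groups could serve equally well. A carboxylic acid, a nitrile or an aminomethyl group at the same place would help separate these possibilities.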